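A few compounds are considered here, and "the series" means these few. Any claim that something is new, unique, unknown or untested is made for them only; others in the source may bear on it.

Measured compounds in a functional assay on isolated protein for antagonist activity at Orexin/Hypocretin receptor type 1 (Homo sapiens), read by fluorescence, FLIPR and calcium flux, with a stated time of 1 h; on this read-out lower numbers stand for stronger inhibition and higher numbers for weaker inhibition:
compound 1 `COc1ccccc1C(C)NC(=O)COc1cc(C(F)(F)F)c2c(-c3ccccc3)nn(C)c2n1` gives 274 nM
compound 2 `COc1cccc(C(C)NC(=O)COc2cc(C(F)(F)F)c3c(-c4ccccc4)nn(C)c3n2)c1` gives 20 nM
compound 3 `COc1ccc(CNC(=O)COc2cc(C(F)(F)F)c3c(-c4ccccc4)nn(C)c3n2)cc1` gives 800 nM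

Compound 3 stands highest of the three, as a 2.9-fold higher number from compound 1 to compound 3 (0.47 log units; beyond the scatter) and a 40-fold higher number from compound 2 to compound 3 (1.60 log units; beyond the scatter) show. Compound 4 `Cc1nn(C)c(C)c1[C@H](C)NC(=O)COc1cc(C(F)(F)F)c2c(-c3ccccc3)nn(C)c2n1` is not yet measured; it differs from compound 3 by 1-(1,3,5-trimethyl-1H-pyrazol-4-yl)ethyl in place of 4-methoxybenzyl on an amide-type nitrogen. Among the measured compounds shown here, the steps that bear on this are the two in which a 1-(methoxyphenyl)ethyl group gave way to a methoxybenzyl group on the same amide-type nitrogen, one modest and one large, both raising the number. For the measured compounds named here, compound 4 restores an ethyl-linked ring, though the ring itself has no precedent among the measured compounds, so a lower number than compound 3 is expected, of moderate size. Compound 4 is therefore estimated at 100 nM, between 20 nM and 500 nM, which is the expected 8.0-fold lower number from compound 3 to compound 4 (0.90 log units; beyond the scatter).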

Compound 4, inhibition constant: 7 nM
The estimate for compound 4 lay 14-fold (1.15 log units) above the measured number; measured number outside the range, below it.
By their numbers in this assay, from the lowest: compound 4; then compound 2; then compound 1; then compound 3.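

In this assay, the best number at this amide-type nitrogen comes from a five-membered aromatic ring with 2 hetero atoms rather than from a methoxyphenyl ring, as the 1-(1,3,5-trimethyl-1H-pyrazol-4-yl)ethyl group surpasses both 1-(methoxyphenyl)ethyl groups (a 2.9-fold lower number from compound 2 to compound 4 (0.46 log units; beyond the scatter); a 39-fold lower number from compound 1 to compound 4 (1.59 log units; beyond the scatter)). Against 4-methoxybenzyl, the change is the largest step in the series (a 110-fold lower number from compound 3 to compound 4 (2.06 log units; beyond the scatter)). Nothing available explains this gain.

The compounds shown leave open how much depends on the defined stereocentre, since its mirror-image form does not appear. They also leave open whether a pyrazole without methyl groups or a pyridine ring would keep the number.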